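Cyclohexyl on the ether oxygen: working notes on compound 3

The source may hold more compounds than are shown below. What is called first, only, known or untested is meant among the compounds shown, and "the series" means these compounds.

Values in a functional assay on NCI-H460 cells (Homo sapiens) for cytotoxicity, read by MTT assay, with a stated time of 96 h (a higher number here means a weaker inhibitor, a lower number a stronger inhibitor), for the measured compounds
- compound 1 `CNc1nc(C)c2cc(-c3cnc(OC)c(NS(=O)(=O)c4ccc(F)cc4F)c3)cc(OC3CCOC(C)(C)C3)c2n1` (250 nM)
- compound 2 `CNc1nc(C)c2cc(-c3cnc(OC)c(NS(=O)(=O)c4ccc(F)cc4F)c3)cc(OCC3CCOCC3)c2n1` (400 nM)

For the measured compounds named here, compound 2 lies within the scatter of compound 1, the only other measured compound, so no order is drawn between them. Compound 3 `CNc1nc(C)c2cc(-c3cnc(OC)c(NS(=O)(=O)c4ccc(F)cc4F)c3)cc(OC3CCCCC3)c2n1` keeps the shared core and carries cyclohexyl in place of (oxan-4-yl)methyl on an oxygen on an aromatic ring. Going by the values given here, one measured step bears on this change, made at the same kind of oxygen (a 1.6-fold higher number from compound 1 to compound 2 (0.20 log units; within the scatter)). That step stayed within the scatter, although it exchanged one ring-bearing substituent for another. From the compounds shown here alone, compound 1 and compound 2 both carry a ring with a hetero atom, so a ring of carbon only remains untested. On this single step, no shift beyond the scatter is expected in this assay, in either direction. The expected step is small (a 1.3-fold lower number from compound 2 to compound 3 (0.12 log units; within the scatter)). For compound 3 the estimated value is 300 nM (expected range 120 nM to 750 nM).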

Compound 3, half-maximal inhibitory concentration: 1700 nM
The estimate for compound 3 lay 5.7-fold (0.75 log units) below the measured number; measured number above the stated range.
By their numbers in this assay, from the lowest: compounds 1 and 2 (each within the scatter of the next); then compound 3.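

In this assay, this oxygen on an aromatic ring no longer appears indifferent to its substituent: cyclohexyl in place of (oxan-4-yl)methyl gives (a 4.3-fold higher number from compound 2 to compound 3 (0.63 log units; beyond the scatter)), and cyclohexyl in place of 2,2-dimethyloxan-4-yl gives (a 6.8-fold higher number from compound 1 to compound 3 (0.83 log units; beyond the scatter)), whereas the two groups with a hetero atom in the ring stay within the scatter of each other. Among these three compounds, the ring of carbon only stands apart with the highest number and neither compound 1 nor compound 2 goes against that reading, but neither step changes the ring atom alone: (oxan-4-yl)methoxy to cyclohexyloxy also alters the link to the ring, and the step from compound 1 also removes two methyl groups. The data shown offer no explanation for this shift.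

Whether the ring oxygen alone accounts for the difference remains open, and plain oxan-4-yl on this oxygen would separate that atom from the link and the two methyl groups. From the compounds shown here alone, it is also open whether another hetero atom can take its place, as in piperidin-4-yl, which carries a ring amine.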